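This account rests on a few compounds, and the source may have more. Where it says the series, first, only, none or still open, it means among the compounds named here.

Measured compounds in a functional assay on HeLa cells (Homo sapiens) for cytotoxicity, read by cell counting, with a stated time of 48 h; on this read-out lower numbers stand for an effect already at smaller amounts and higher numbers for an effect only at larger amounts of compound:
- compound 1, `C=CCCCCCCCCC(=O)O[C@H]1[C@H](O)[C@H](n2ccc(N)nc2=O)O[C@@H]1CO`: 0.05 ug/mL
- compound 2, `CCCCCCCCCCCCCC(=O)O[C@H]1[C@H](O)[C@H](n2ccc(N)nc2=O)O[C@@H]1CO`: 0.08 ug/mL

Going by the values given here, compound 2 has the highest number of the two measured so far, with compound 1 nearest; the step of a 1.6-fold higher number from compound 1 to compound 2 (0.20 log units; within the scatter) places the two within the scatter, so no order between them can be claimed in this assay.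

Compound 3, `CCCCCCCCCCCC(=O)O[C@H]1[C@H](O)[C@H](n2ccc(N)nc2=O)O[C@@H]1CO`, has not yet been measured in this assay. It differs from compound 2 by hydrogen in place of ethyl on a saturated chain carbon, ten or more bonds along the chain from a carbonyl carbon, so the ester chain is shortened at its outer end while the core and the ester linkage are unchanged.

Among the compounds with values here, no measured step covers this exact change. Within the data shown here, the only step, a 1.6-fold higher number from compound 1 to compound 2 (0.20 log units; within the scatter), also concerns the outer end of the chain but at a different place along it, and it stays within the scatter. On that basis the step from compound 2 to compound 3 is expected to stay within the scatter as well, with no direction that can be told, which is the meaning of the estimated step of no change at the digits printed from compound 2 to compound 3 (within the scatter). Compound 3 is therefore estimated at 0.08 ug/mL in this assay, with a range from 0.03 ug/mL to 0.2 ug/mL.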

Compound 3, concentration for half-maximal effect: 0.08 ug/mL
Beside the measured number, compound 3's estimate shows no gap at the digits printed; the range from low to high includes it.
By their numbers in this assay, from the lowest: compounds 1, 2 and 3 (each within the scatter of the next).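

In this assay, going by these compounds alone, the step of no change at the digits printed from compound 2 to compound 3 (within the scatter) gives the first reading of hydrogen in place of ethyl on a saturated chain carbon, ten or more bonds along the chain from a carbonyl carbon, and shortening the outer end of the ester chain in this way does not register. The step of a 1.6-fold higher number from compound 1 to compound 3 (0.20 log units; within the scatter) also stays within the scatter, so this difference at the outer end of the chain gives no separation, and the three ester chains shown cannot be told apart in this assay on these numbers. Nothing at hand bears on why these changes at the outer end of the chain leave the read-out within the scatter.

As far as these compounds go, it remains open how far the ester chain can be shortened or lengthened before the number moves beyond the scatter, as a much shorter chain or a longer chain would show. It is also open whether an amine or a carboxylic acid at the outer end of the chain would read the same way as the plain chain ends shown here.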